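The compounds below may be only part of what the source reports. "The series", "measured", "known", "first", "only" and "open" are said of these compounds alone.

Three compounds share one core and differ only in the group on the saturated chain carbon bound to a nitrogen on an aromatic ring. In an ADME assay on cells (Homo sapiens) for cytotoxicity, read by polymerase chain reaction, with a stated time of 3 days (on this read-out higher numbers stand for lower toxicity in this test and lower numbers for higher toxicity in this test), compound 1 `CCCNc1nc(C)c(-c2nc3ccccc3s2)c(N[C@@H]2C[C@H](CO)[C@@H](O)[C@H]2O)n1` reaches only a limit of the test, not a number, namely > 25000 nM. Compound 2 `Cc1nc(NCC(C)C)nc(N[C@@H]2C[C@H](CO)[C@@H](O)[C@H]2O)c1-c1nc2ccccc2s1` gives 10000 nM in this assay, and compound 3 `Cc1nc(NCc2ccsc2)nc(N[C@@H]2C[C@H](CO)[C@@H](O)[C@H]2O)c1-c1nc2ccccc2s1` gives 6000 nM. Compound 3 therefore holds the lowest of the two real numbers, but the gap a 1.7-fold lower number from compound 2 to compound 3 (0.22 log units; within the scatter) is within the scatter, so the two cannot be ordered. The steps of an at least 2.5-fold lower number from compound 1 to compound 2 (0.39 log units; beyond the scatter) and an at least 4.1-fold lower number from compound 1 to compound 3 (0.61 log units; beyond the scatter) are beyond the scatter, yet each begins from a limit of > 25000 nM in this assay, at which 1 of the 3 values shown sits, and so only sets a floor on their size.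

Compound 4 `Cc1nc(NCc2cccnc2)nc(N[C@@H]2C[C@H](CO)[C@@H](O)[C@H]2O)c1-c1nc2ccccc2s1` differs from compound 3 by pyridin-3-yl in place of thiophen-3-yl on a saturated chain carbon bound to a nitrogen on an aromatic ring. Going by the values given here, no measured step exchanges one aromatic ring for another; the nearest comparison, a 1.7-fold lower number from compound 2 to compound 3 (0.22 log units; within the scatter), stays within the scatter. The expected step is therefore no change at the digits printed from compound 3 to compound 4 (within the scatter), not beyond the scatter. Compound 4 is estimated at 6000 nM in this assay, with a likely range from 2500 nM to 15000 nM.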

Compound 4, half-maximal cytotoxic concentration: 5000 nM
Compound 4: the middle estimate sits 1.2-fold (0.08 log units) above what was measured; the range from low to high includes it.
By their numbers in this assay, from the lowest: compounds 4, 3 and 2 (each within the scatter of the next). At a limit, above all of these: compound 1.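

Going by these compounds alone, putting a six-membered aromatic ring in place of a five-membered one on this saturated chain carbon is the first exchange of one aromatic ring for another, and in this assay it gives a 1.2-fold lower number from compound 3 to compound 4 (0.08 log units; within the scatter), so pyridin-3-yl and thiophen-3-yl cannot be told apart here. Pyridin-3-yl also cannot be separated from isopropyl, with a 2.0-fold lower number from compound 2 to compound 4 (0.30 log units; within the scatter). Only the exchange for ethyl lies beyond the scatter, with an at least 5.0-fold lower number from compound 1 to compound 4 (0.69 log units; beyond the scatter), and its true size stays open, since it starts from a limit: the limit of > 25000 nM in this assay, at which 1 of the 4 values shown sits.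

On these data alone, it remains open whether a carboxylic acid or an amine on this carbon would shift the number beyond the scatter. The same question stands for a plain phenyl ring, which would show how a six-membered aromatic ring without a hetero atom compares with pyridin-3-yl.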